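Swapping the aryl group on the triazole nitrogen of compound 1

The source may hold more compounds than are shown below. What is called first, only, known or untested is meant among the compounds shown, and "the series" means these compounds.

Compound 1 `CC(C)c1ccc(-n2nc(-c3ccccc3)nc2CNc2ccc(C(=O)NO)cc2)cc1` is tested in an assay on Sf9 cells for inhibition of protein deacetylase HDAC6 (Homo sapiens), read by fluorescence, with a stated time of 40 min, tested at 100 nM (on this read-out higher numbers stand for more inhibition at the one concentration tested (going by the name of the read-out) and lower numbers for less inhibition), where compound 1 gives 52.6%. Compound 2 `CNC(=O)c1ccc(NCc2nc(-c3ccccc3)nn2-c2ccccc2)cc1`, measured in this assay, gives -3.6%. Compound 1 thus stands highest of the two numbers, with compound 2 far below it, beyond the scatter. Compound 3 `Cc1cc(C)cc(-n2nc(-c3ccccc3)nc2CNc2ccc(C(=O)NO)cc2)c1` differs from compound 1 by 3,5-dimethylphenyl in place of 4-isopropylphenyl on an aromatic nitrogen. Within the data shown here, with no comparable step measured, the change is expected to alter inhibition little, at most a modest downward shift within the scatter. The expected step of a number 6.6 percentage points lower from compound 1 to compound 3 (within the scatter) is therefore small. Compound 3 is estimated to give 46%, between 26% and 66%.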

Compound 3, a percentage reported as inhibition, at one concentration (the size of the read-out at that concentration, not a potency): 49.8%
Compound 3: middle estimate off by 3.8 percentage points, on the low side; low and high end bracket the measured number.
By their numbers in this assay, from the lowest: compound 2; then compounds 3 and 1 (each within the scatter of the next).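

In this assay, 3,5-dimethylphenyl in place of 4-isopropylphenyl on the aromatic nitrogen gives a number 2.8 percentage points lower from compound 1 to compound 3 (within the scatter). Among these compounds, this is the first step measured at this position, and it shows that these two differently substituted phenyl groups cannot be told apart here. No measured evidence accounts for this result.

Still open, as far as these compounds go, is whether inhibition holds up with a phenyl group carrying an amine or a carboxylic acid on this nitrogen. From the compounds shown here alone, a longer chain, such as n-butyl, in place of the ring is equally open.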